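Branching One Amine Chain: Expected Effect on Receptor Binding

This account rests on a few compounds, and the source may have more. Where it says the series, first, only, none or still open, it means among the compounds named here.

Three measured compounds share one core and differ only in the two chains attached to the amino nitrogen. In an assay on HEK293 cells for displacement of a labelled ligand from corticotropin-releasing factor receptor 1 (Homo sapiens) (on this read-out higher numbers stand for weaker inhibition and lower numbers for stronger inhibition), compound 1 `CCCN(CC1CC1)c1cc(C)nc2c(-c3ccc(Cl)cc3Cl)nn(C)c12` gives 1.7 nM, compound 2 `CCCCN(CCCC)c1cc(C)nc2c(-c3ccc(Cl)cc3Cl)nn(C)c12` gives 0.62 nM, and compound 3 `CCCCCN(CCC)c1cc(C)nc2c(-c3ccc(Cl)cc3Cl)nn(C)c12` gives 1.2 nM. Compound 2 holds the lowest number of the three, though its distance to compound 3 is small: a 1.9-fold higher number from compound 2 to compound 3 (0.29 log units; within the scatter). The clearer gap is a 2.7-fold lower number from compound 1 to compound 2 (0.44 log units; beyond the scatter), while the remaining pair shows a 1.4-fold lower number from compound 1 to compound 3 (0.15 log units; within the scatter).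

Compound 4 `CCCCN(c1cc(C)nc2c(-c3ccc(Cl)cc3Cl)nn(C)c12)C(CC)CC` carries a change on one side of that amine: pentan-3-yl in place of butyl on a nitrogen on an aromatic ring. Going by the values given here, two measured steps bear on this change, as both also reshape the chains on this nitrogen: a 2.7-fold lower number from compound 1 to compound 2 (0.44 log units; beyond the scatter), which lies beyond the scatter, and a 1.9-fold higher number from compound 2 to compound 3 (0.29 log units; within the scatter), which lies within it. Moving carbons into one longer, branched chain while keeping a butyl on the other side resembles the second of these more than the first, so the expected step is of modest size or none beyond the scatter, leaning toward a higher number: a 1.6-fold higher number from compound 2 to compound 4 (0.21 log units; within the scatter). Compound 4 is therefore estimated at 1 nM, with a range from 0.4 nM to 2.5 nM.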

Compound 4, inhibition constant: 7 nM
Estimate against measurement, compound 4: 7.0-fold (0.85 log units) below; measured number outside the range, above it.
By their numbers in this assay, from the lowest: compounds 2, 3 and 1 (each within the scatter of the next, the first and the last beyond it); then compound 4.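

Putting pentan-3-yl in place of butyl on the nitrogen gives an 11-fold higher number from compound 2 to compound 4 (1.05 log units; beyond the scatter) in this assay, a larger step than any among compounds 1, 2 and 3, where the chains on this nitrogen were rearranged with much less effect on the number. So this position does not treat all chains alike: the swap adds only one carbon, going from 4 heavy atoms to 5, with no ring, no hydrogen-bond donor or acceptor and no charge entering, yet binding falls far more than the earlier changes would suggest. Nothing presented here explains why this particular chain is so much worse at this position.

The compounds shown leave open whether the loss tracks the branched shape of pentan-3-yl or its size, since no smaller branched chain, such as isopropyl or butan-2-yl, stands on this nitrogen alongside butyl. On these data alone, it also remains open how a chain with a ring attached directly to the nitrogen, such as cyclopentyl, or one carrying an ether oxygen, would fare in this place.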